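The compounds below may be only part of what the source reports. "The series", "measured", "known", "first", "only" and "open" are said of these compounds alone.

Compound 1: `O=S(=O)(Nc1ccc(-c2nc3ccccc3o2)cc1)c1ccccc1Cl` — > 100000 nM
Compound 2: `C=Cc1ccc(S(=O)(=O)Nc2ccc(-c3nc4ccccc4o3)cc2)cc1` — > 100000 nM

In an assay on cells for inhibition of HSP60/HSP10 (Homo sapiens), with a stated time of 60 min (a lower number here means a stronger inhibitor, a higher number a weaker inhibitor), compound 1 gives > 100000 nM, which is a limit of the assay and not a number. Compound 2 gives > 100000 nM in this assay, again a limit rather than a number. For the measured compounds named here, the only measured step, a step that the two limits leave unreadable from compound 1 to compound 2, therefore cannot be read, and the whole picture so far is the limit of > 100000 nM in this assay, at which 2 of the 2 values shown sit.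

Compound 3, `COc1ccccc1S(=O)(=O)Nc1ccc(-c2nc3ccccc3o2)cc1`, has yet to be measured. It differs from compound 2 in one place: 2-methoxyphenyl in place of 4-vinylphenyl on a sulfonyl sulfur. Going by the values given here, no measured step bears on this change, and nothing among the values shown points toward a readable gain or loss in this assay. Compound 3 is therefore expected to stand near 150000 nM, within 40000 nM to 600000 nM, most likely reported once more as a limit. The step this estimate means from compound 2 to compound 3 is a step that the limit leaves unreadable from compound 2 to compound 3, an expectation of no movement beyond the usual scatter.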

Compound 3, half-maximal inhibitory concentration: > 100000 nM
Compound 3: only a limit was reported (the forecaster's own chance of this, stated with the estimate: 75%); the middle value does not contradict the limit.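

For the compounds shown here, no step among compound 1, compound 2 and compound 3 can be read, as each result is a limit and not a number: the limit of > 100000 nM in this assay, at which 3 of the 3 values shown sit. The compounds shown leave open whether any group on the sulfonyl sulfur would give a readable value in this assay.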